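Acetamido in place of nitro: compound 1 to compound 3

The source may report more compounds than this note shows. Statements on the series, on what has been measured and on what is new or still open speak of the compounds shown alone.

Measured compounds:
compound 1, `COc1cc(OC)c(/C=C/S(=O)(=O)Cc2ccc(OC)c([N+](=O)[O-])c2)c(OC)c1`, gives 660 nM in a functional assay on HCT-116 cells (Homo sapiens) for cytotoxicity, read by MTT assay, with a stated time of 72 h; a lower number here means a stronger inhibitor of growth, a higher number a weaker inhibitor of growth.
compound 2, `COc1cc(/C=C/S(=O)(=O)Cc2ccc(OC)c([N+](=O)[O-])c2)cc(OC)c1`, gives only a limit of the assay, > 30000 nM, in this assay.

For the measured compounds named here, compound 1 carries the only proper number in the set. Going by the values given here, compound 2 returns no number at all, only (the limit of > 30000 nM in this assay, at which 1 of the 2 values shown sits), and the pair differ in more than one place, so no single step between measured compounds can be drawn from them.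

Compound 3, `COc1cc(OC)c(/C=C/S(=O)(=O)Cc2ccc(OC)c(NC(C)=O)c2)c(OC)c1`, differs from compound 1 in one place: acetamido in place of nitro on an aromatic carbon. Among the compounds with values here, no measured step bears on this kind of change, so the expectation rests on compound 1 alone, with 660 nM as the starting point. A moderate loss of growth inhibition in this assay is expected, of a size beyond the usual scatter but not large, so that the step from compound 1 to compound 3 is estimated as a 3.0-fold higher number from compound 1 to compound 3 (0.48 log units; beyond the scatter). Compound 3 is accordingly expected to give about 2000 nM, with a likely range from 500 nM to 8000 nM.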

Compound 3, concentration for 50% growth inhibition: 150 nM
Compound 3: the middle estimate sits 13-fold (1.12 log units) above what was measured; measured number outside the range, below it.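

Acetamido in place of nitro, on the aromatic carbon ortho to a methoxy group, gives a 4.4-fold lower number from compound 1 to compound 3 (0.64 log units; beyond the scatter) in this assay, the first single-place step in the series. The nitro group is therefore not required at this position for growth inhibition in this core, and a group carrying an amide hydrogen, a hydrogen-bond donor absent from nitro, is accepted there with a gain rather than a loss. Nothing measured in the series accounts for the size of this gain or ties it to the donor, the carbonyl or the larger group.

Going by these compounds, with only nitro and acetamido compared at this position, it remains open whether a free amine, a methanesulfonamide or an amide with a longer chain would hold, extend or lose the gain seen with compound 3. Compound 2 gives > 30000 nM, which is a limit of the assay and differs from compound 1 in more than one place, so the contribution of each methoxy group on the other aromatic ring, and whether acetamido would have the same effect on that core, cannot be read.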